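Sulfonamide series: ethyl to isopropyl on the sulfonyl sulfur

The source may report more compounds than this note shows. Statements on the series, on what has been measured and on what is new or still open speak of the compounds shown alone.

Measured so far:
compound 1, `O=S(=O)(Nc1cccc2c1CCCC2c1c[nH]cn1)C1CC1`, 537 nM
compound 2, `CCS(=O)(=O)Nc1cccc2c1CCCC2c1c[nH]cn1`, 46.8 nM

Both compounds share the same core and differ only in the group on the sulfonyl sulfur. Among the compounds with values here, in an assay on isolated protein for binding affinity to Alpha-1A adrenergic receptor (Rattus norvegicus), read by radioligand binding (on this read-out lower numbers stand for stronger inhibition and higher numbers for weaker inhibition), compound 2 gives the lower of the two numbers, with compound 1 as its only neighbour, and the step of an 11-fold lower number from compound 1 to compound 2 (1.06 log units; beyond the scatter) is the sole comparison available.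

Compound 3, `CC(C)S(=O)(=O)Nc1cccc2c1CCCC2c1c[nH]cn1`, is not yet measured. Its change from compound 2 is methyl in place of hydrogen on a saturated chain carbon bound to a saturated chain carbon and a sulfonyl sulfur, so the ethyl on the sulfonyl sulfur becomes isopropyl.

Within the data shown here, the one measured step bears on this only loosely: it runs from cyclopropyl to ethyl, and compound 3 carries neither of these groups. That step was large, and in it the smaller ethyl gave the lower number. The isopropyl of compound 3 is a further heavy atom beyond ethyl. For compound 3 a step in the opposite direction, upward in number and smaller than the measured one, is expected as a 2.4-fold higher number from compound 2 to compound 3 (0.37 log units; beyond the scatter). Compound 3 is therefore estimated at 110 nM in this assay, with a range from 40 nM to 300 nM.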

Compound 3, inhibition constant: 1150 nM
Compound 3: middle estimate off by 10-fold (1.02 log units), on the low side; measured number outside the range, above it.
By their numbers in this assay, from the lowest: compound 2; then compound 1; then compound 3.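

In this assay, the group on the sulfonyl sulfur proves more sensitive than the cyclopropyl to ethyl comparison alone could show: methyl in place of hydrogen on the saturated chain carbon, which turns ethyl into isopropyl, gives a 25-fold higher number from compound 2 to compound 3 (1.39 log units; beyond the scatter), a large step from the addition of 1 heavy atom. The change from cyclopropyl to isopropyl gives a 2.1-fold higher number from compound 1 to compound 3 (0.33 log units; beyond the scatter), a modest step that still lies beyond the scatter, so among these three groups ethyl alone gives a low number, and compound 3 gives the highest number of the set. The data offer no measurement that accounts for these steps.

The compounds shown leave open whether the low number depends on ethyl itself or would persist with a methyl or a longer straight chain such as n-propyl on the sulfonyl sulfur. They also do not settle how this position responds to a group of another kind, such as trifluoromethyl or a dimethylamino group, or whether the isopropyl penalty holds on other cores.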